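Moving the Sulfur Around the Thiophene Ring

The source may hold more compounds than are shown below. What is called first, only, known or untested is meant among the compounds shown, and "the series" means these compounds.

Compound 1, `CCN(C/C=C/C#CC(C)(C)C)Cc1cccc(OCCNS(=O)(=O)c2cccs2)c1`: 450 nM
Compound 2, `CCN(C/C=C/C#CC(C)(C)C)Cc1cccc(OCCN(C)S(=O)(=O)c2cccs2)c1`: 60 nM

Of the compounds shown here, two have been measured so far in a functional assay on HepG2 cells for inhibition of squalene monooxygenase (Homo sapiens); on this read-out higher numbers stand for weaker inhibition and lower numbers for stronger inhibition. Compound 1 gives 450 nM, and compound 2 gives 60 nM. Among the compounds with values here, the single measured step, a 7.5-fold lower number from compound 1 to compound 2 (0.88 log units; beyond the scatter), is the only guide available. Compound 2 therefore stands at the lowest of the two numbers, with compound 1 the nearest neighbour at a clearly higher value.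

The next compound, compound 3 `CCN(C/C=C/C#CC(C)(C)C)Cc1cccc(OCCN(C)S(=O)(=O)c2ccsc2)c1`, differs from compound 2 in one place: thiophen-3-yl in place of thiophen-2-yl on a sulfonyl sulfur. Within the data shown here, no measured step bears on this change. Among the measured compounds shown here, the step of a 7.5-fold lower number from compound 1 to compound 2 (0.88 log units; beyond the scatter) concerns a methyl on the sulfonamide nitrogen, and both compounds measured so far carry the thiophen-2-yl group. With the same atoms merely joined differently, and nothing measured to point either way, the expected step is none beyond the scatter, written as a 1.2-fold higher number from compound 2 to compound 3 (0.07 log units; within the scatter). Compound 3 is thus estimated at 70 nM, with a range from 25 nM to 200 nM.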

Compound 3, half-maximal inhibitory concentration: 250 nM
Compound 3: middle estimate off by 3.6-fold (0.55 log units), on the low side; measured number above the stated range.
By their numbers in this assay, from the lowest: compound 2; then compounds 3 and 1 (each within the scatter of the next).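

In this assay, the thiophene ring on the sulfonyl sulfur proves not to be interchangeable with its isomer: putting thiophen-3-yl in place of thiophen-2-yl, with the same atoms joined differently, gives a 4.2-fold higher number from compound 2 to compound 3 (0.62 log units; beyond the scatter). So far only the sulfonamide nitrogen had been seen to move the number, and now the way the ring is attached to the sulfonyl sulfur is shown to count as well. When the whole end group is compared, with the methyl and the ring change taken together, the result is a 1.8-fold lower number from compound 1 to compound 3 (0.26 log units; within the scatter), so these two compounds cannot be told apart here, and no measurement at hand explains why the ring attachment matters.

Going by these compounds, it remains open how a compound with thiophen-3-yl and a hydrogen on the sulfonamide nitrogen would behave, which would show whether the methyl has the same effect with either ring. On these data alone, it is also open whether a phenyl or a furan-2-yl on the sulfonyl sulfur would give a number closer to that of compound 2 or to that of compound 3.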